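Metabolic stability notes on compounds 1 to 3

The compounds below may be only part of what the source reports. "The series", "measured", "known", "first", "only" and "open" are said of these compounds alone.

Measured so far:
compound 1 `c1ccc2c(c1)CN[C@H](CN(CCCN1CCNCC1)[C@H]1CCCc3cccnc31)C2`: 99%
compound 2 `CC(C)N1CCN(CCCN(C[C@H]2Cc3ccccc3CN2)[C@H]2CCCc3cccnc32)CC1`: 46%

In an ADME assay on microsomes from liver (Homo sapiens) for metabolic stability, read by LC-MS, with a stated time of 10 min, tested at 0.5 uM (a higher number here means that more of the compound is left, a lower number that less of the compound is left), compound 1 gives 99%, the highest of the two numbers. Compound 2 gives 46% in this assay, a number far lower and beyond the scatter. Within the data shown here, the two structures differ in more than one place, so no single step connects them; only the two values themselves are known.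

Compound 3 `c1cnc2c(c1)CN[C@H](CN(CCCN1CCNCC1)[C@H]1CCCc3cccnc31)C2` is the next candidate for this assay. It differs from compound 1 by a group of 10 heavy atoms (8 carbon, 2 nitrogen; one six-membered non-aromatic ring with 1 hetero atom, one six-membered aromatic ring with 1 hetero atom) in place of a group of 10 heavy atoms (9 carbon, 1 nitrogen; one six-membered non-aromatic ring with 1 hetero atom, one six-membered aromatic ring of carbon only), on a saturated chain carbon bound to an amine nitrogen. Among the measured compounds shown here, no step of this kind has been measured, so the size of the effect cannot be read from any pair already in hand. Compound 1 already stands near the top of the scale, which leaves little room for an upward move. The expected step of a number 9 percentage points lower from compound 1 to compound 3 (within the scatter) is small, downward at most, and is not expected to go beyond the scatter. For compound 3 the estimated value in this assay is 90%, with a range from 70% to 100%.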

Compound 3, percent of the compound remaining: 100%
The estimate for compound 3 lay 10 percentage points below the measured number, within the range that was stated.
By their numbers in this assay, from the lowest: compound 2; then compounds 1 and 3 (each within the scatter of the next).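

In this assay, the series now has its first pair differing in one place, and it gives a number 1 percentage points higher from compound 1 to compound 3 (within the scatter). On a saturated chain carbon bound to an amine nitrogen, the 1,2,3,4-tetrahydroisoquinolin-3-yl group can thus give way to a group of the same heavy-atom count, with a six-membered aromatic ring with 1 hetero atom replacing the six-membered aromatic ring of carbon only, without a step beyond the scatter in the percent of compound remaining. No measurement at hand accounts for this result or gives any property of either group.

Both numbers lie close to the top of the scale, so this one pair cannot show whether the same change would leave the read-out unmoved in a compound with less of the parent left after the incubation, and a single step at this place gives no trend. Also open, from the compounds shown here alone, is how this assay would read for the same shared core with a chlorine atom or a methoxy group on the aromatic ring of the group at this place.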